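The compounds below may be only part of what the source reports. "The series", "measured", "known", "first", "only" and "open" are said of these compounds alone.

Compound 1, `COc1ccccc1/C=C(/SCc1ccc(C)cc1)C(=O)c1ccc(Cl)cc1`: 10000 nM
Compound 2, `Cc1ccc(CS/C(=C/c2ccccc2Br)C(=O)c2ccc(Cl)cc2)cc1`: 10000 nM
Compound 3, `Cc1ccc(CS/C(=C/c2ccc(O)cc2)C(=O)c2ccc(Cl)cc2)cc1`: 10000 nM

In a functional assay on DU-145 cells (Homo sapiens) for inhibition, read by trypan blue exclusion, with a stated time of 96 h (on this read-out higher numbers stand for weaker inhibition of growth and lower numbers for stronger inhibition of growth), compound 1 gives 10000 nM, and it stands level with compounds 2 and 3. The step of no change at the digits printed from compound 1 to compound 2 (within the scatter), which puts bromo in place of methoxy on an aromatic carbon, and the step of no change at the digits printed from compound 1 to compound 3 (within the scatter), which puts 4-hydroxyphenyl in place of 2-methoxyphenyl on a double-bonded chain carbon bound to a double-bonded chain carbon, both stay within the scatter, as does no change at the digits printed from compound 2 to compound 3 (within the scatter). Every measured change so far sits on the aryl group attached to the chain, and none of them moves the read-out.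

Compound 4, `COc1ccccc1/C=C(/Sc1ccc(Br)cc1)C(=O)c1ccc(Cl)cc1`, alters a different part of the shared core: 4-bromophenyl in place of 4-methylbenzyl on a sulfur. Within the data shown here, no measured step touches the sulfur substituent, so the three flat steps bear on it only by showing how little the whole series has moved in this assay. With nothing pointing in either direction, the step of no change at the digits printed from compound 1 to compound 4 (within the scatter) is expected to stay within the scatter. Compound 4 is therefore estimated at 10000 nM in this assay, with a range from 3000 nM to 30000 nM.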

Compound 4, concentration for 50% growth inhibition: 10000 nM
Estimate against measurement, compound 4: no gap at the digits printed, within the range that was stated.
By their numbers in this assay, from the lowest: compounds 1, 2, 3 and 4 (each within the scatter of the next).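

In this assay, among these compounds, the step of no change at the digits printed from compound 1 to compound 4 (within the scatter) gives the sulfur substituent its first measured change, since the earlier steps all sat on the aryl group attached to the chain. It shows that (4-methylbenzyl)sulfanyl can give way to (4-bromophenyl)sulfanyl with the read-out unmoved, even though the replacement keeps one six-membered aromatic ring while exchanging an all-carbon group for one that carries bromine. No evidence is available that would explain this flat result at the sulfur, and none is offered here.

Because the swap alters the group's carbon framework and brings in bromine in a single step, the compounds shown cannot say what either change would do alone, and both groups compared lack hydrogen-bond donors, acceptors and net charge. On these data alone, whether an amine, a carboxylic acid or a longer chain on the sulfur would move the growth-inhibition value away from the level shared by all four compounds remains open, as does the effect of any change to the rest of the shared core.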